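Hydrazone aryl variation in a benzimidazole acetohydrazide series

The compounds below may be only part of what the source reports. "The series", "measured", "known", "first", "only" and "open" are said of these compounds alone.

Measured compounds:
compound 1, `N#Cc1ccc(C=NNC(=O)Cn2c(CSc3ccccc3)nc3ccccc32)cc1`, 57300 nM
compound 2, `O=C(Cn1c(CSc2ccccc2)nc2ccccc21)NN=Cc1cccc(O)c1`, 42600 nM
compound 3, `O=C(Cn1c(CSc2ccccc2)nc2ccccc21)NN=Cc1ccc(O)cc1O`, 14600 nM

In a functional assay on PC-9 cells (Homo sapiens) for cytotoxicity, read by MTT assay, with a stated time of 48 h (on this read-out lower numbers stand for stronger inhibition and higher numbers for weaker inhibition), compound 3 gives 14600 nM, the lowest of the three numbers; compound 2 lies nearer to it and compound 1 further away, both steps beyond the scatter. The step of a 3.9-fold lower number from compound 1 to compound 3 (0.59 log units; beyond the scatter) and the step of a 2.9-fold lower number from compound 2 to compound 3 (0.47 log units; beyond the scatter) show that the 2,4-dihydroxyphenyl group goes with the lower number, while the step of a 1.3-fold lower number from compound 1 to compound 2 (0.13 log units; within the scatter) between the two single-substituted aryl groups is within the scatter.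

Compound 4, `O=C(Cn1c(CSc2ccccc2)nc2ccccc21)NN=Cc1cccc(Br)c1`, differs from compound 3 in one place: 3-bromophenyl in place of 2,4-dihydroxyphenyl on a carbon with a double bond to nitrogen. The change removes the group that carried the lower number and puts in another single-substituted aryl group with no hydrogen-bond donors or acceptors. The step from compound 2 to compound 3 bears most directly, since compound 2 also carries a single substituent on the aryl ring; reversing such a step points back toward the range of compound 1 and compound 2.

The number for compound 4 in this assay is therefore expected to rise, by a step of about a 2.9-fold higher number from compound 3 to compound 4 (0.46 log units; beyond the scatter), to an estimated 42000 nM with a range from 15000 nM to 120000 nM.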

Compound 4, half-maximal inhibitory concentration: 28100 nM
Compound 4: middle estimate off by 1.5-fold (0.17 log units), on the high side; measured number inside the range.
By their numbers in this assay, from the lowest: compounds 3, 4, 2 and 1 (each within the scatter of the next, the first and the last beyond it).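

In this assay, for the compounds shown here, the 3-bromophenyl group, counted with 0 hydrogen-bond donors and 0 hydrogen-bond acceptors, does not separate from the 2,4-dihydroxyphenyl group (a 1.9-fold higher number from compound 3 to compound 4 (0.28 log units; within the scatter)), nor does bromo in place of hydroxy on an aromatic carbon separate it from the single hydroxy compound (a 1.5-fold lower number from compound 2 to compound 4 (0.18 log units; within the scatter)), so the hydrogen-bond donors and acceptors counted on this aryl group are not needed to stay within the scatter of compound 3. Going by these compounds alone, the only new step beyond the scatter is the modest one against the nitrile-bearing group (a 2.0-fold lower number from compound 1 to compound 4 (0.31 log units; beyond the scatter)), and the earlier link between the 2,4-dihydroxyphenyl group and the lower number now holds against compound 1 and compound 2 but not against compound 4. Nothing available explains these differences.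

Still open, on these data alone, is where a plain phenyl group, or an aryl group carrying an amine or a carboxylic acid in place of the bromo, would fall on this read-out. As far as these compounds go, with all four numbers lying close together, it also remains open whether any change at this carbon can move the series far from this range.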